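One stereocentre changed at the limit of the assay

A few compounds are considered here, and "the series" means these few. Any claim that something is new, unique, unknown or untested is made for them only; others in the source may bear on it.

For the measured compounds named here, in a functional assay on Vero cells (Chlorocebus sabaeus) for inhibition (a higher number here means a weaker inhibitor, a lower number a stronger inhibitor), compound 1 (`Nc1nc(F)nc2c1ncn2[C@H]1CS[C@@H](CO)O1`) gives 5600 nM and is the only compound with a numeric reading so far. Compound 2 (`OC[C@H]1O[C@H](n2cnc3c(O)ncnc32)CS1`) reads > 100000 nM and this is a limit of the assay. Compound 3 (`CNc1ncnc2c1ncn2[C@@H]1CS[C@@H](CO)O1`) reads > 100000 nM and this too is a limit, so its true position is not known. The data thus show the limit of > 100000 nM in this assay, at which 2 of the 3 values shown sit, and compound 3 stands there.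

Compound 4 (`CNc1ncnc2c1ncn2[C@H]1CS[C@@H](CO)O1`) is the stereoisomer of compound 3: the two compounds have the same atoms and bonds and differ only in configuration as drawn: 1 of 2 stereo elements differ; a stereocentre at a saturated ring carbon is drawn S in compound 3 and R in compound 4 and nothing else changes. Going by the values given here, the one measured step touching compound 3 is a step that the two limits leave unreadable from compound 2 to compound 3 and it concerns methylamino in place of hydroxy on an aromatic carbon. It does not involve configuration and has no readable size, so it offers nothing to carry over to this change.

Among the compounds with values here, the only guide to a reading within range is compound 1 at 5600 nM in this assay and this supports a cautious expectation of a stronger inhibitor. Another limit reading is about as likely for compound 4. The expected change is an at least 3.3-fold lower number from compound 3 to compound 4 (0.52 log units; beyond the scatter) and its size is highly uncertain. For compound 4 the estimate is 30000 nM with an expected range of 5000 nM to 100000 nM in this measurement.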

Compound 4, half-maximal inhibitory concentration: > 100000 nM
Compound 4 gave a limit, no number (the forecaster's own chance of this, stated with the estimate: 50%); middle value at least 3.3-fold (0.52 log units) away from the limit.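

Compound 4 reads > 100000 nM in this assay, and this is a limit of the assay. For the compounds shown here, compound 3 sits at the same limit, so no step between compound 3 and compound 4 can be read. The compounds shown leave open whether changing the configuration at that saturated ring carbon alters inhibition at all in this assay.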